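Tert-butyl for ethyl on the shared core: sigma binding

The compounds below may be only part of what the source reports. "The series", "measured", "known", "first", "only" and "open" are said of these compounds alone.

Measured so far in an assay on brain for displacement of a labelled ligand from Sigma non-opioid intracellular receptor 1 (Cavia porcellus); a higher number here means a weaker inhibitor, a lower number a stronger inhibitor:
- compound 1 `CC[C@@]1(c2ccccc2)OCC[C@@H](CCNCc2ccccc2)O1`: 20 nM
- compound 2 `CC[C@]1(c2ccccc2)OCC[C@H](CCNCc2ccccc2)O1`: 28 nM
- compound 3 `C[C@]1(c2ccccc2)OCC[C@H](CCN)O1`: > 10000 nM
- compound 4 `CC(C)(C)[C@@]1(c2ccccc2)OCC[C@@H](CCNCc2ccccc2)O1`: not yet measured

Compound 1 gives the lowest of the two numbers in this assay; the nearest is a 1.4-fold higher number from compound 1 to compound 2 (0.15 log units; within the scatter), so the two mirror images cannot be told apart here, a point that rests on (the fact that compounds 1 and 2 differ only in the configuration as drawn). For the measured compounds named here, for compound 3 the assay reports only a limit, (the limit of > 10000 nM in this assay, at which 1 of the 3 values shown sits), and no number; compound 3 also differs from compound 1 in more than one place, so no single step can be drawn from it.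

Compound 4 differs from compound 1 by tert-butyl in place of ethyl on a saturated ring carbon. Going by the values given here, no measured step alters this position, so nothing in the data sets the size or direction of the change. The expectation is therefore a step of a 2.0-fold higher number from compound 1 to compound 4 (0.30 log units; within the scatter), not clearly beyond the scatter. Compound 4 is estimated at 40 nM, with a range from 10 nM to 200 nM.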

Compound 4, inhibition constant: 128 nM
Estimate against measurement, compound 4: 3.2-fold (0.51 log units) below; measured number inside the range.
By their numbers in this assay, from the lowest: compounds 1 and 2 (each within the scatter of the next); then compound 4. At a limit, above all of these: compound 3.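

In this assay, the saturated ring carbon between two ring oxygen atoms now proves sensitive to the group it carries: tert-butyl in place of ethyl gives a 6.4-fold higher number from compound 1 to compound 4 (0.81 log units; beyond the scatter). The step is modest, and compound 4 still returns a measured number, 128 nM, so the larger group at this position does not abolish binding in this assay. Nothing shown here bears on why the number rises with this change.

Open, on these data alone, is how the number runs between and beyond these two groups on the shared core, for example with isopropyl or cyclohexyl at this position. Also open, as far as these compounds go, is whether the mirror image of compound 4 would stay within the scatter of compound 4, as the mirror-image pair of compounds 1 and 2 does.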